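A few compounds are considered here, and "the series" means these few. Any claim that something is new, unique, unknown or untested is made for them only; others in the source may bear on it.

The measured compounds are compound 1 `COc1ccccc1/C=C/C(=O)c1nc2ccccc2[nH]1`, compound 2 `O=C(/C=C/c1cccnc1)c1nc2ccccc2[nH]1` and compound 3 `O=C(/C=C/c1ccccn1)c1nc2ccccc2[nH]1`. In a functional assay on HCT-116 cells (Homo sapiens) for antiproliferative activity, read by MTT assay, with a stated time of 48 h (a lower number here means a stronger inhibitor, a higher number a weaker inhibitor), compound 1 gives 4790 nM, compound 2 gives 15300 nM and compound 3 gives 60 nM.

Compound 1 thus holds the second highest of the three numbers: compound 2 sits higher and compound 3 sits far lower. Compound 4 `O=C(/C=C/c1ccccc1Br)c1nc2ccccc2[nH]1` differs from compound 1 by a single change, (bromo in place of methoxy on an aromatic carbon). Going by the values given here, the only step among the measured compounds, a 260-fold lower number from compound 2 to compound 3 (2.41 log units; beyond the scatter), concerns which pyridinyl is attached and says nothing about exchanging one substituent for another on a six-membered ring of carbon only. Among the compounds with values here, no measured pair speaks to this change, so no step beyond the scatter is expected from compound 1 to compound 4, a 1.1-fold lower number from compound 1 to compound 4 (0.03 log units; within the scatter). Compound 4 is therefore estimated at 4500 nM, between 1200 nM and 16000 nM.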

Compound 4, half-maximal inhibitory concentration: 16400 nM
Compound 4: middle estimate off by 3.6-fold (0.56 log units), on the low side; the whole stated range lies below it.
By their numbers in this assay, from the lowest: compound 3; then compound 1; then compounds 2 and 4 (each within the scatter of the next).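

In this assay, the step to bromo in place of methoxy, a 3.4-fold higher number from compound 1 to compound 4 (0.53 log units; beyond the scatter), shows that this aromatic carbon, ortho to a large group, is sensitive to which substituent it carries. In this pair, methoxy gives the lower number, so bromo does not serve as a neutral replacement here. No measurement at hand bears on why the number rises. The compounds shown leave open how a chloro, a hydroxy or an amine at this same place would compare with methoxy and bromo. They also leave open whether either group would give a different number on another carbon of this ring.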